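The source may report more compounds than this note shows. Statements on the series, on what has been measured and on what is new or still open speak of the compounds shown alone.

Working notes on the series. In a functional assay on OVCAR-4 cells (Homo sapiens) for inhibition, read by sulforhodamine B assay, with a stated time of 48 h (a lower number here means a stronger inhibitor of growth, a higher number a weaker inhibitor of growth), compound 1 `COc1cc(C)cc(-c2c(-c3ccnc(-c4ccc(N(C)C)cc4)c3)cnn2CC#N)c1` gives 270 nM, the lowest number among the three measured compounds. Compound 2 `COc1cc(C)cc(-c2nn(CC#N)cc2-c2ccnc(-c3ccc(N(C)C)cc3)c2)c1` gives 549 nM, a higher number than compound 1 and beyond the scatter, though no single-point difference between these two is tabulated here. Compound 3 `Cc1cc(O)cc(-c2nn(CC#N)cc2-c2ccnc(-c3ccc(N(C)C)cc3)c2)c1` gives 4850 nM, the highest number of the set. For the measured compounds named here, the one measured single-point step is an 8.8-fold higher number from compound 2 to compound 3 (0.95 log units; beyond the scatter), the change being hydrogen in place of methyl on an oxygen on an aromatic ring; it shows that the series is sensitive to small edits on that ring.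

Compound 4 `COc1cc(C)cc(-c2c(-c3ccnc(-c4ccc(C(C)=O)cc4)c3)cnn2CC#N)c1` is not yet measured. It differs from compound 1 by acetyl in place of dimethylamino on an aromatic carbon. Going by the values given here, no measured step touches this position or this pair of groups, so the measured data give no direct anchor for its size or direction. The change keeps one hydrogen-bond acceptor and adds a double bond outside aromatic rings; with nothing measured to lean on, a change of modest size in either direction is plausible, and the expectation is centred on a somewhat higher number, with wide bounds, as a 1.9-fold higher number from compound 1 to compound 4 (0.27 log units; within the scatter). Compound 4 is therefore estimated at 500 nM, within a range from 120 nM to 2200 nM.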

Compound 4, concentration for 50% growth inhibition: 5130 nM
Compound 4: middle estimate off by 10-fold (1.01 log units), on the low side; measured number above the stated range.
By their numbers in this assay, from the lowest: compound 1; then compound 2; then compounds 3 and 4 (each within the scatter of the next).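

In this assay, the change from 4-(dimethylamino)phenyl to 4-acetylphenyl gives a 19-fold higher number from compound 1 to compound 4 (1.28 log units; beyond the scatter), so this position, para to a large group, clearly discriminates between these two groups. The result also shows that matching heavy-atom counts and matching hydrogen-bond donor and acceptor counts do not ensure a similar number here, since dimethylamino and acetyl are the same on all of these counts. The earlier sensitivity rested only on an 8.8-fold higher number from compound 2 to compound 3 (0.95 log units; beyond the scatter), an edit on an oxygen on a different aromatic ring, and the series now shows a step beyond the scatter at a second site, though nothing at hand explains this one.

The compounds shown leave open whether dimethylamino lowers the number or acetyl raises it, a question that a plain hydrogen, a methoxy group or a primary amine at this position would help to settle. They also leave open whether the same exchange would give a step of similar size on compound 2, whose shared core is arranged differently from that of compound 1.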